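The source may report more compounds than this note shows. Statements on the series, on what has been measured and on what is new or still open speak of the compounds shown alone.

Working notes on the series.

Of the compounds shown here, two share the core and have been tested so far. Compound 1 `Cc1ccc(S(=O)(=O)N2C/C(=C\c3ccccc3F)C(=O)/C(=C/c3ccccc3F)C2)cc1` in a functional assay on SMMC-7721 cells (Homo sapiens) for cytotoxicity, read by MTT assay, with a stated time of 24 h (on this read-out lower numbers stand for stronger inhibition and higher numbers for weaker inhibition), gives 4100 nM. Compound 2 `O=C1/C(=C/c2cccc(F)c2)CN(S(=O)(=O)c2ccc(F)cc2)C/C1=C\c1cccc(F)c1` in this assay gives 13500 nM, the highest of the two numbers; the gap to compound 1 is beyond the usual scatter, so compound 2 is the weaker of the pair on this read-out. Among the measured compounds shown here, compound 1 and compound 2 differ in more than one place, so no single step between them can be read.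

Compound 3 `CC(=O)Nc1ccc(S(=O)(=O)N2C/C(=C\c3cccc(F)c3)C(=O)/C(=C/c3cccc(F)c3)C2)cc1` is not yet measured. It differs from compound 2 by acetamido in place of fluoro on an aromatic carbon. For the measured compounds named here, no measured pair in the set shows this change, so its size is unknown. The expectation is a modest step, possibly none beyond the scatter; the estimated step from compound 2 to compound 3 is a 1.4-fold lower number from compound 2 to compound 3 (0.13 log units; within the scatter). For compound 3 the expected value in this assay is 10000 nM, within a range from 4000 nM to 25000 nM.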

Compound 3, half-maximal inhibitory concentration: 10300 nM
For compound 3 the middle estimate is 1.0-fold (0.01 log units) below the measured one; the measured number falls inside the stated range.
By their numbers in this assay, from the lowest: compound 1; then compounds 3 and 2 (each within the scatter of the next).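

Among the compounds shown here, this is the first step that can be read at a single place: in this assay, going from 4-fluorophenyl to 4-acetamidophenyl gives a 1.3-fold lower number from compound 2 to compound 3 (0.12 log units; within the scatter) on the aromatic carbon para to a large group. At this position, in the setting of compound 2, a single fluorine can therefore be exchanged for the larger acetamido, which brings a hydrogen-bond donor and a hydrogen-bond acceptor, without a difference beyond the scatter. No available evidence bears on why the two groups read so closely.

From the compounds shown here alone, whether an amine or a carboxylic acid at this position would also stay within the scatter remains open. Steps from compound 1 cannot be read, so it is also open whether this exchange behaves the same way with the fluorines placed as in compound 1.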